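Aryl swap on the cinnamate ester: compound 3 to compound 4

The compounds below may be only part of what the source reports. "The series", "measured", "known", "first", "only" and "open" are said of these compounds alone.

Three esters sharing one core were tested in a functional assay on the whole organism (strain Kunming) with Mus musculus as the target, with a stated time of 0.5 h, at a dose of 100 mg/kg by the intraperitoneal route; on this read-out higher numbers stand for a weaker effect at the one dose given and lower numbers for a stronger effect. Compound 1 `COc1cc(OC)c(OC)cc1/C=C/COC(=O)/C=C/c1ccc(OC)c(OC)c1` gives 100%, compound 2 `COc1cc(OC)c(OC)cc1/C=C/COC(=O)/C=C/c1ccccc1Cl` gives 100%, and compound 3 `COc1cc(OC)c(OC)cc1/C=C/COC(=O)/C=C/c1ccc(F)cc1` gives 100%, so compound 3 stands level with both. The steps of no change at the digits printed from compound 1 to compound 2 (within the scatter), no change at the digits printed from compound 1 to compound 3 (within the scatter) and no change at the digits printed from compound 2 to compound 3 (within the scatter) show that exchanging the aryl group on the double-bonded chain carbon has so far left the read-out unmoved. Compound 4 `COc1cccc(/C=C/C(=O)OC/C=C/c2cc(OC)c(OC)cc2OC)c1` differs from compound 3 as follows: 3-methoxyphenyl in place of 4-fluorophenyl on a double-bonded chain carbon bound to a double-bonded chain carbon. As all three aryl exchanges bore no change, the expected step is no change at the digits printed from compound 3 to compound 4 (within the scatter). Compound 4 is therefore estimated at 100%, with a range from 88% to 100% in this assay.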

Compound 4, a percentage reported as activity, at one dose (the size of the read-out at that dose, not a potency): 100%
The estimate for compound 4 equals the measured number at the digits printed, within the range that was stated.
By their numbers in this assay, from the lowest: compounds 1, 2, 3 and 4 (each within the scatter of the next).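

In this assay, setting 3-methoxyphenyl, which counts one hydrogen-bond acceptor, in place of 4-fluorophenyl, which counts none, gives no change at the digits printed from compound 3 to compound 4 (within the scatter). The exchange against 2-chlorophenyl gives no change at the digits printed from compound 2 to compound 4 (within the scatter), and the new single-place link to the dimethoxy ester, hydrogen in place of methoxy on an aromatic carbon, gives no change at the digits printed from compound 1 to compound 4 (within the scatter). No measurement here explains this flat result.

The compounds shown leave open whether an amine or a carboxylic acid in place of the aryl group, or a longer chain at this place, would shift the read-out.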